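The source may hold more compounds than are shown below. What is called first, only, known or untested is meant among the compounds shown, and "the series" means these compounds.

Working notes on the series. Compound 1 `CCNC(=O)/C=C1\CCc2ccc(F)cc21` gives 63% in a functional assay on the whole organism with Rattus norvegicus as the target, at a dose of 20 mg/kg by the oral route; on this read-out higher numbers stand for more inhibition at the one dose given (going by the name of the read-out) and lower numbers for less inhibition; compound 2 `O=C(/C=C1\CCc2ccc(F)cc21)N1CCCC1` gives 18%; compound 3 `CNC(=O)/C=C1\CCc2ccc(F)cc21` gives 38%, the second highest of the three numbers, separated from both others by steps beyond the scatter: a number 25 percentage points lower from compound 1 to compound 3 (beyond the scatter) and a number 20 percentage points higher from compound 2 to compound 3 (beyond the scatter). Compound 4 `CON(C)C(=O)/C=C1\CCc2ccc(F)cc21` is not yet measured; the change from compound 3 is methoxy in place of hydrogen on an amide-type nitrogen. For the measured compounds named here, the nearest precedent is the loss of the amide hydrogen on going to the pyrrolidin-1-yl amide, a number 45 percentage points lower from compound 1 to compound 2 (beyond the scatter), a large fall; the change on the saturated chain carbon, a number 25 percentage points lower from compound 1 to compound 3 (beyond the scatter), was only modest. A fall beyond the scatter is therefore expected for compound 4, a number 23 percentage points lower from compound 3 to compound 4 (beyond the scatter). Compound 4 is estimated at 15%, within a range of 0% to 35%.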

Compound 4, a percentage reported as inhibition, in the whole organism at one dose (the size of the read-out at that dose, not a potency): 14%
For compound 4 the middle estimate is 1 percentage points above the measured one; low and high end bracket the measured number.
By their numbers in this assay, from the lowest: compounds 4 and 2 (each within the scatter of the next); then compound 3; then compound 1.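

Methoxy in place of hydrogen on an amide-type nitrogen gives a number 24 percentage points lower from compound 3 to compound 4 (beyond the scatter) in this assay and shows that a change at this nitrogen alone, with the shared core kept, is enough to lower the number. With a number 4 percentage points lower from compound 2 to compound 4 (within the scatter) and a number 49 percentage points lower from compound 1 to compound 4 (beyond the scatter) as the other two steps, the two amides without an amide hydrogen, one in a ring and one open-chain, stand together at the low end of the series. Nothing measured here bears on the cause of this.

As far as these compounds go, whether dimethylamino on the carbonyl carbon would read like compound 4 stays open, and with it whether the methoxy adds anything beyond the loss of the amide hydrogen. Also open, from the compounds shown here alone, is how a longer chain, such as propylamino in place of ethylamino, would read.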